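The source may report more compounds than this note shows. Statements on the series, on what has been measured and on what is new or still open speak of the compounds shown alone.

Measured so far:
- compound 1, `CCCCCCCC/C=C\CCCCCCCC(=O)Nc1nnc(S[C@@H]2O[C@H](COC(C)=O)[C@H](OC(C)=O)[C@H](OC(C)=O)[C@H]2OC(C)=O)s1`, gives 26300 nM
- compound 2, `CCCCCCCCCC(=O)Nc1nnc(S[C@@H]2O[C@H](COC(C)=O)[C@H](OC(C)=O)[C@H](OC(C)=O)[C@H]2OC(C)=O)s1`, gives 19400 nM
- compound 3, `CCCCCCCCCCCC(=O)Nc1nnc(S[C@@H]2O[C@H](COC(C)=O)[C@H](OC(C)=O)[C@H](OC(C)=O)[C@H]2OC(C)=O)s1`, gives 27700 nM

These three compounds share one core and differ only in the length and saturation of a fatty chain attached through an amide. In an ADME assay on CHO-K1 cells (Cricetulus griseus) for cytotoxicity, read by MTT assay, with a stated time of 24 h (a lower number here means a stronger inhibitor, a higher number a weaker inhibitor), compound 3 has the highest of the three numbers, yet its gap to compound 1 and to compound 2 lies within the scatter, so none of the three can be called weaker or stronger than another.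

Compound 4, `CCCCCCCCCCCCCCCC(=O)Nc1nnc(S[C@@H]2O[C@H](COC(C)=O)[C@H](OC(C)=O)[C@H](OC(C)=O)[C@H]2OC(C)=O)s1`, is the next step. It differs from compound 3 only in the chain: butyl in place of hydrogen on a saturated chain carbon, ten or more bonds along the chain from a carbonyl carbon.

The steps already seen all concern the same chain. The closest parallel, a chain extension, gave a 1.4-fold higher number from compound 2 to compound 3 (0.15 log units; within the scatter). The other two, a 1.4-fold lower number from compound 1 to compound 2 (0.13 log units; within the scatter) and a 1.1-fold higher number from compound 1 to compound 3 (0.02 log units; within the scatter), were likewise within the scatter. Nothing here suggests that a longer chain moves the number in this assay by more than the scatter, so the expectation for compound 4 is a step of about a 1.0-fold higher number from compound 3 to compound 4 (0.00 log units; within the scatter), with no real direction.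

Compound 4 is therefore estimated at 28000 nM, with a range from 14000 nM to 56000 nM.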

Compound 4, half-maximal inhibitory concentration: 90400 nM
The estimate for compound 4 lay 3.2-fold (0.51 log units) below the measured number; the measured number lies above the stated range.
By their numbers in this assay, from the lowest: compounds 2, 1 and 3 (each within the scatter of the next); then compound 4.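

In this assay, among these compounds, butyl in place of hydrogen on a saturated chain carbon, ten or more bonds along the chain from a carbonyl carbon, gives a 3.3-fold higher number from compound 3 to compound 4 (0.51 log units; beyond the scatter) and is the first change at this position to pass beyond the scatter. The other two comparisons agree, with a 4.7-fold higher number from compound 2 to compound 4 (0.67 log units; beyond the scatter) for hexyl in place of hydrogen and a 3.4-fold higher number from compound 1 to compound 4 (0.54 log units; beyond the scatter) for octyl in place of dec-1-en-1-yl, so compound 4 stands apart from three compounds that remain within the scatter of one another. Chain length alone does not give a simple rule, since compound 1 goes against it: its dec-1-en-1-yl group is longer than the octyl of compound 4, yet compound 4 has the higher number, and no accompanying measurement offers a reason for the jump.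

A decyl group in place of dec-1-en-1-yl would help separate the effect of chain length from that of the double bond in compound 1. On these data alone, it also remains open whether a longer saturated chain than that of compound 4 would raise the number further, and whether a carboxylic acid or an amine at the chain end would change it.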